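The source may report more compounds than this note shows. Statements on the series, on what has been measured and on what is new or still open speak of the compounds shown alone.

Measured compounds:
compound 1 `CCCNC(=O)c1ccc(Oc2nc(-c3c(C)noc3C)cnc2N)cc1` — 32100 nM
compound 2 `Cc1noc(C)c1-c1cnc(N)c(Oc2ccc(C(=O)Nc3cccc(Cl)n3)cc2)n1` — 25500 nM
compound 3 `Cc1noc(C)c1-c1cnc(N)c(Oc2ccc(C(=O)Nc3cc(Cl)ccn3)cc2)n1` — 37900 nM

In a functional assay on HeLa cells (Homo sapiens) for inhibition, read by MTT assay, with a stated time of 72 h (on this read-out higher numbers stand for weaker inhibition and lower numbers for stronger inhibition), compound 2 gives the lowest of the three numbers, yet it does not stand apart from the others: the step of a 1.3-fold lower number from compound 1 to compound 2 (0.10 log units; within the scatter) and the step of a 1.5-fold higher number from compound 2 to compound 3 (0.17 log units; within the scatter) both lie within the scatter, as does a 1.2-fold higher number from compound 1 to compound 3 (0.07 log units; within the scatter), so the three compounds sit together.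

Compound 4 `Cn1cc(-c2cnc(N)c(Oc3ccc(C(=O)Nc4cccc(Cl)n4)cc3)n2)cn1` differs from compound 2 in one place: 1-methyl-1H-pyrazol-4-yl in place of 3,5-dimethyl-1,2-oxazol-4-yl on an aromatic carbon. For the measured compounds named here, every measured step changes only the group on the amide-type nitrogen; none of them touches the five-membered ring on the shared core, so no measured step bears directly on this change. Going by the values given here, the only guidance is that the three measured compounds, differing elsewhere, gave numbers within the scatter of one another.

With nothing pointing in either direction, compound 4 is expected to give a number close to that of compound 2, a step of a 1.2-fold higher number from compound 2 to compound 4 (0.07 log units; within the scatter), not beyond the scatter. Among the compounds with values here, the estimate for compound 4 is 30000 nM, with a range from 8000 nM to 100000 nM, held wide because no measured step speaks to this position.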

Compound 4, half-maximal inhibitory concentration: 38200 nM
Beside the measured number, compound 4's estimate is 1.3-fold (0.10 log units) below it, within the range that was stated.
By their numbers in this assay, from the lowest: compounds 2, 1, 3 and 4 (each within the scatter of the next).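

In this assay, the only step shown at this position, para to an amino group, puts 1-methyl-1H-pyrazol-4-yl in place of 3,5-dimethyl-1,2-oxazol-4-yl and gives (a 1.5-fold higher number from compound 2 to compound 4 (0.18 log units; within the scatter)). The earlier compounds shown here differed only on the amide-type nitrogen, whereas this pair shows that one five-membered aromatic ring with 2 hetero atoms can stand in for another on the shared core without the two numbers being told apart. Nothing shown bears on why the two compounds read alike.

As far as these compounds go, it remains open whether this position responds to any change at all, since both groups here are closely matched in their counted features. A morpholine or a primary amine on that aromatic carbon, in place of 3,5-dimethyl-1,2-oxazol-4-yl, would test whether a number beyond the scatter of compound 2 can be reached.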